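The source may hold more compounds than are shown below. What is called first, only, known or untested is meant among the compounds shown, and "the series" means these compounds.

Compound 3 `CCOC(=O)c1cnc(N2CCN(Cc3ccc(F)cc3)CC2)nc1Oc1c(C)cc(-c2ccc(C#N)cc2)cc1C` carries a 4-fluorophenyl on a saturated chain carbon bound to an amine nitrogen in a ring. In an ADME assay on MT4 cells (Homo sapiens) for cytotoxicity, read by MTT assay, with a stated time of 4 days (on this read-out lower numbers stand for higher toxicity in this test and higher numbers for lower toxicity in this test), compound 3 reaches only a limit, > 117000 nM, not a number. Compound 1 `CCOC(=O)c1cnc(N2CCN(Cc3cccc(C(F)(F)F)c3)CC2)nc1Oc1c(C)cc(-c2ccc(C#N)cc2)cc1C` gives a limit too in this assay, > 125000 nM. Compound 2 `CCOC(=O)c1cnc(N2CCN(Cc3ccccc3C(F)(F)F)CC2)nc1Oc1c(C)cc(-c2ccc(C#N)cc2)cc1C` likewise stops at a limit in this assay, > 125000 nM. The steps a step that the two limits leave unreadable from compound 1 to compound 2, a step that the two limits leave unreadable from compound 1 to compound 3 and a step that the two limits leave unreadable from compound 2 to compound 3 therefore have no readable size; every value shown sits at the limit of > 117000 nM in this assay, at which 1 of the 3 values shown sits, or (the limit of > 125000 nM in this assay, at which 2 of the 3 values shown sit). Compound 4 `CCOC(=O)c1cnc(N2CCN(Cc3cccc(F)c3)CC2)nc1Oc1c(C)cc(-c2ccc(C#N)cc2)cc1C` differs from compound 3 by 3-fluorophenyl in place of 4-fluorophenyl on a saturated chain carbon bound to an amine nitrogen in a ring. Among the measured compounds shown here, with all measured values at limits, no step of readable size bears on this change, and no movement beyond the scatter is expected in this assay. The estimate for compound 4 is 125000 nM, from 100000 nM to 160000 nM. The expected step is a step that the limit leaves unreadable from compound 3 to compound 4.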

Compound 4, half-maximal cytotoxic concentration: > 125000 nM
Compound 4: a limit, no number; the forecaster's own chance of this, stated with the estimate: 90%; the middle value lies on the limit itself.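

In this assay no new step can be read between compound 4 and compound 1, compound 2 or compound 3, since all four values are limits: the limit of > 125000 nM in this assay, at which 3 of the 4 values shown sit. The compounds shown leave open where any true half-maximal cytotoxic concentration lies, and whether these benzyl changes alter it.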